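Fluorocyclopropyl Amide on the Shared Core: an Estimate

A few compounds are considered here, and "the series" means these few. Any claim that something is new, unique, unknown or untested is made for them only; others in the source may bear on it.

Measured so far:
compound 1, `CCCC(=O)N1CC2CC(C1)N2`: 110%
compound 2, `O=C(C1CCC1)N1CC2CC(C1)N2`: 99%
compound 3, `O=C(C1CCCC1)N1CC2CC(C1)N2`: 68%

In an assay on SH-EP1 cells for agonist activity at Neuronal acetylcholine receptor; alpha4/beta2 (Homo sapiens), read by FLIPR and calcium flux (a lower number here means a smaller maximal response, a higher number a larger maximal response), compound 2 gives 99%, the second highest of the three numbers. Its nearest neighbour is compound 1 with 110%, and the furthest is compound 3 with 68%. Compound 4, `O=C([C@H]1C[C@@H]1F)N1CC2CC(C1)N2`, differs from compound 2 by 2-fluorocyclopropyl in place of cyclobutyl on a carbonyl carbon. For the measured compounds named here, the only step that bears on this change in the acyl group is a number 11 percentage points lower from compound 1 to compound 2 (beyond the scatter), a modest move that went beyond the scatter. Going by the values given here, with compound 3 also in view, larger carbocycles on the carbonyl carbon gave the lower numbers, and the entering group is the smaller ring; the fluorine has no precedent here. Compound 4 is therefore expected to give a step of a number 4 percentage points higher from compound 2 to compound 4 (within the scatter), within the scatter. The estimate for compound 4 is 103%, between 82% and 122%.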

Compound 4, largest response reached (Emax), in percent of the reference or control that the assay uses: 100%
Beside the measured number, compound 4's estimate is 3 percentage points above it, and the stated range covers the measured number.
By their numbers in this assay, from the lowest: compound 3; then compounds 2, 4 and 1 (each within the scatter of the next, the first and the last beyond it).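

In this assay, 2-fluorocyclopropyl in place of cyclobutyl on the carbonyl carbon gives no change outside the scatter (a number 1 percentage points higher from compound 2 to compound 4 (within the scatter)), so this place tolerates a three-membered ring carrying fluorine. Measured against the propyl amide, the new group also stays within the scatter (a number 10 percentage points lower from compound 1 to compound 4 (within the scatter)), whereas the step from compound 1 to compound 2 went beyond it (a number 11 percentage points lower from compound 1 to compound 2 (beyond the scatter)). No measurement shown accounts for this result.

Going by these compounds, what plain cyclopropyl would give on the same carbonyl carbon remains open, so the contributions of the fluorine and the three-membered ring cannot be separated. On these data alone, the other stereoisomers of 2-fluorocyclopropyl also remain open.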